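Alkylation of an oxime hydroxy in a trimethoxyphenyl naphthyl series

The source may report more compounds than this note shows. Statements on the series, on what has been measured and on what is new or still open speak of the compounds shown alone.

Compound 1 `COc1ccc(/C(=N/O)c2cccc3ccccc23)c(OC)c1OC`: > 20000 nM
Compound 2 `COc1ccc(C(O)(Cc2ccc(C)cc2)c2cccc3ccccc23)c(OC)c1OC`: > 20000 nM
Compound 3 `COc1ccc(C(c2ccc(OCCO)cc2)c2cccc3ccccc23)c(OC)c1OC`: 16600 nM

Three measured compounds share a core of a trimethoxyphenyl carbon joined to a naphthyl group, and all were tested in a functional assay on THP-1 cells (Homo sapiens) for inhibition, read by sulforhodamine B assay, with a stated time of 48 h; a lower number here means a stronger inhibitor, a higher number a weaker inhibitor. Compound 1 gives only a limit in this assay, > 20000 nM. Compound 2 likewise gives only a limit in this assay, > 20000 nM. Compound 3 gives a numerical value in this assay, 16600 nM. No pair among these three differs in a single place, so no measured step can be drawn from them; what the values show is that none of the three reaches a strong inhibition, and compound 1 stands at the limit alongside compound 2, as summarised by the limit of > 20000 nM in this assay, at which 2 of the 3 values shown sit.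

Compound 4 `CCOC(=O)/C=C/CO/N=C(/c1ccc(OC)c(OC)c1OC)c1cccc2ccccc12`, not yet measured, differs from compound 1 by 3-(ethoxycarbonyl)prop-2-en-1-yl in place of hydrogen on an oxygen, in words 3-(ethoxycarbonyl)prop-2-en-1-yl in place of hydrogen on an oxygen. Going by the values given here, with no measured step to lean on, the expected step from compound 1 to compound 4 is an at least 1.4-fold lower number from compound 1 to compound 4 (0.15 log units; that floor lies within the scatter), which is to say a modest move toward stronger inhibition that may not clear the usual scatter. Compound 4 is therefore estimated at 14000 nM in this assay, with a range from 4000 nM to 40000 nM.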

Compound 4, half-maximal inhibitory concentration: > 20000 nM
Compound 4 gave a limit, no number (the forecaster's own chance of this, stated with the estimate: 45%); middle value at least 1.4-fold (0.15 log units) from the limit.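

Compound 1 and compound 4 each give only a limit in this assay, so no step between them can be read: the limit of > 20000 nM in this assay, at which 3 of the 4 values shown sit.

Whether 3-(ethoxycarbonyl)prop-2-en-1-yl in place of hydrogen on an oxygen changes inhibition at all, and in which direction, remains open in the compounds shown.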